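The source may report more compounds than this note shows. Statements on the series, on what has been measured and on what is new or still open speak of the compounds shown alone.

Compound 1 `CC(=O)Nc1cccc(NC(=O)COc2ccc3c(=O)ccoc3c2)c1` gives 136 nM in an assay on isolated protein for inhibition of Rho-associated protein kinase 2 (Homo sapiens), read by scintillation counting, radiometric assay and 33P incorporation, with a stated time of 40 min, in the presence of a further agent that is not named here; on this read-out lower numbers stand for stronger inhibition and higher numbers for weaker inhibition.
Compound 2 `COC(=O)c1ccc(C(=O)Nc2cccc(NC(=O)COc3ccc4c(=O)ccoc4c3)c2)cc1` gives 29 nM in this assay.
Compound 3 `O=C(COc1ccc2c(=O)ccoc2c1)Nc1cccc(NC(=O)c2cccc([N+](=O)[O-])c2)c1` gives 41 nM in this assay.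

Among the three measured compounds, compound 3 stands second highest: its nearest neighbour is compound 2, its furthest is compound 1. Compound 4 `NCc1ccc(C(=O)Nc2cccc(NC(=O)COc3ccc4c(=O)ccoc4c3)c2)cc1` is not yet measured. It differs from compound 3 by 4-(aminomethyl)phenyl in place of 3-nitrophenyl on a carbonyl carbon. Among the measured compounds shown here, the steps that bear on this are a 4.7-fold lower number from compound 1 to compound 2 (0.67 log units; beyond the scatter) and a 3.3-fold lower number from compound 1 to compound 3 (0.52 log units; beyond the scatter), both an aryl group replacing methyl on the carbonyl carbon, and a 1.4-fold higher number from compound 2 to compound 3 (0.15 log units; within the scatter), an exchange of one aryl group for another. The two aryl variants sit within the scatter of each other, so a further aryl exchange is expected to give little change beyond the scatter in this assay. For compound 4 the estimate is 35 nM, within 12 nM to 100 nM. The expected step is a 1.2-fold lower number from compound 3 to compound 4 (0.07 log units; within the scatter).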

Compound 4, half-maximal inhibitory concentration: 66 nM
Compound 4: the middle estimate sits 1.9-fold (0.28 log units) below what was measured; the measured number falls inside the stated range.
By their numbers in this assay, from the lowest: compounds 2, 3 and 4 (each within the scatter of the next, the first and the last beyond it); then compound 1.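

With 4-(aminomethyl)phenyl on the carbonyl carbon, this assay still shows a step beyond the scatter against methyl, with a 2.1-fold lower number from compound 1 to compound 4 (0.31 log units; beyond the scatter), so a third aryl group also gives a lower number than methyl. Among the compounds shown here, the exchange of 3-nitrophenyl for this group stays within the scatter, with a 1.6-fold higher number from compound 3 to compound 4 (0.21 log units; within the scatter), whereas aminomethyl in place of methoxycarbonyl on an aromatic carbon gives a 2.3-fold higher number from compound 2 to compound 4 (0.36 log units; beyond the scatter), the first exchange between aryl groups here to pass beyond the scatter. Nothing given here explains these steps. On these data alone, it remains open how a carboxylic acid in place of methoxycarbonyl, or a longer chain ending in an amine in place of aminomethyl, would read in this assay.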